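The source may hold more compounds than are shown below. What is called first, only, known or untested is meant among the compounds shown, and "the series" means these compounds.

Of the compounds shown here, three have numbers so far in a functional assay on A549 cells (Homo sapiens) for cytotoxicity, read by sulforhodamine B assay, with a stated time of 48 h; a lower number here means a stronger inhibitor, a higher number a weaker inhibitor. Compound 1 `COc1ccc(/C=C/C(=O)c2cccc(Br)c2)cc1OC` gives 9430 nM, compound 2 `COc1ccc(/C=C/C(=O)c2cccc(-c3cccc(F)c3)c2)cc1O` gives 500 nM, and compound 3 `COc1ccc(/C=C/C(=O)c2cccc(-c3cccc(F)c3)c2)cc1` gives 2440 nM. Compound 3 therefore holds the middle place of the three, with a lower number than compound 1 and a higher number than compound 2, both gaps lying beyond the scatter.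

Compound 4 `COc1ccc(/C=C/C(=O)c2cccc(-c3cccc(F)c3)c2)cc1OC` departs from compound 3 in one place: methoxy in place of hydrogen on an aromatic carbon. This is methoxy in place of hydrogen on an aromatic carbon, ortho to a methoxy group and meta to a large group.

Among the measured compounds shown here, one measured step bears directly on that carbon: a 4.9-fold higher number from compound 2 to compound 3 (0.69 log units; beyond the scatter), a modest step beyond the scatter, with hydrogen in place of hydroxy on an aromatic carbon. Read backwards, it links a group at that carbon with a lower number. For the measured compounds named here, that group is hydroxy rather than methoxy, however, and no measured pair shows methoxy in place of hydrogen, so only part of the size is carried over.

A small move to a lower number is expected in this assay, possibly not clearing the scatter. The expected step is a 1.6-fold lower number from compound 3 to compound 4 (0.21 log units; within the scatter). For compound 4 the estimated value is 1500 nM, with an expected range of 500 nM to 5000 nM.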

Compound 4, half-maximal inhibitory concentration: 1940 nM
The estimate for compound 4 lay 1.3-fold (0.11 log units) below the measured number; low and high end bracket the measured number.
By their numbers in this assay, from the lowest: compound 2; then compounds 4 and 3 (each within the scatter of the next); then compound 1.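

Methoxy at this carbon, ortho to a methoxy group, does not separate from hydrogen in this assay: the data give a 1.3-fold lower number from compound 3 to compound 4 (0.10 log units; within the scatter). The hydroxy of compound 2 stands apart from both neighbours, since methyl on that oxygen gives a 3.9-fold higher number from compound 2 to compound 4 (0.59 log units; beyond the scatter), and the earlier step for removing the hydroxy was a 4.9-fold higher number from compound 2 to compound 3 (0.69 log units; beyond the scatter); among these three compounds, then, only the hydroxy form differs beyond the scatter at this carbon. The other substituent also counts with the two methoxy groups in place, as 3-fluorophenyl in place of bromo gives a 4.9-fold lower number from compound 1 to compound 4 (0.69 log units; beyond the scatter), and no measured evidence at hand accounts for any of these steps.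

Still open, as far as these compounds go, is how specific the lower number of compound 2 is to hydroxy, a question that an amine or a carboxylic acid at this carbon, or an ethoxy group in place of the methoxy of compound 4, would help to settle. Also open, from the compounds shown here alone, is whether the 3-fluorophenyl step holds with hydroxy at this carbon, and whether the fluoro on that ring matters at all.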